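Removing the methoxy group from the aryl amide of compound 3

The source may hold more compounds than are shown below. What is called first, only, known or untested is meant among the compounds shown, and "the series" means these compounds.

Three analogues sharing one core have been tested in a functional assay on L1210 cells (Mus musculus) for cytotoxicity; a higher number here means a weaker inhibitor, a lower number a stronger inhibitor. Compound 1 `O=C(/C=C/C(=O)N1C/C(=C\c2ccccc2)C(=O)/C(=C/c2ccccc2)C1)Nc1ccc(Cl)c(Cl)c1` gives 7500 nM. Compound 2 `CC(=O)c1ccc(NC(=O)/C=C/C(=O)N2C/C(=C\c3ccccc3)C(=O)/C(=C/c3ccccc3)C2)cc1` gives 5500 nM. Compound 3 `COc1ccc(NC(=O)/C=C/C(=O)N2C/C(=C\c3ccccc3)C(=O)/C(=C/c3ccccc3)C2)cc1` gives 6800 nM, a number that sits with those of compound 1 and compound 2, since a 1.1-fold lower number from compound 1 to compound 3 (0.04 log units; within the scatter) and a 1.2-fold higher number from compound 2 to compound 3 (0.09 log units; within the scatter) both fall inside the usual scatter, as does a 1.4-fold lower number from compound 1 to compound 2 (0.13 log units; within the scatter).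

Compound 4 `O=C(/C=C/C(=O)N1C/C(=C\c2ccccc2)C(=O)/C(=C/c2ccccc2)C1)Nc1ccccc1` differs from compound 3 by a single change: hydrogen in place of methoxy on an aromatic carbon. For the measured compounds named here, the steps that bear on this are the ones altering the same aryl ring, a 1.1-fold lower number from compound 1 to compound 3 (0.04 log units; within the scatter) and a 1.2-fold higher number from compound 2 to compound 3 (0.09 log units; within the scatter), and neither moved the number beyond the scatter. Swapping the substituent on that ring, whether to acetyl, chloro pairs or methoxy, left the read-out essentially flat, so the bare phenyl is expected to behave the same way.

Compound 4 is therefore estimated at 7000 nM, with a plausible range of 4000 nM to 12000 nM. The expected step is a 1.0-fold higher number from compound 3 to compound 4 (0.01 log units; within the scatter), that is, no change beyond the scatter.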

Compound 4, half-maximal inhibitory concentration: 3600 nM
Estimate against measurement, compound 4: 1.9-fold (0.29 log units) above; measured number below the stated range.
By their numbers in this assay, from the lowest: compounds 4, 2, 3 and 1 (each within the scatter of the next, the first and the last beyond it).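

In this assay, taking the substituent off the aryl ring gives a 1.9-fold lower number from compound 3 to compound 4 (0.28 log units; within the scatter) for methoxy and a 1.5-fold lower number from compound 2 to compound 4 (0.18 log units; within the scatter) for acetyl, so neither group can be told apart from hydrogen at this position. For the compounds shown here, the two chloro groups are the only substitution here that separates from the bare phenyl, with a 2.1-fold lower number from compound 1 to compound 4 (0.32 log units; beyond the scatter), the first step to pass the scatter, and a modest one. Nothing available explains that step.

The compounds shown leave open whether a single chloro group on this ring would give the same step as the pair. They also leave open whether an amine or a carboxylic acid in place of methoxy would carry the number beyond the scatter.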